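Aryl swap on the diaryl chain carbon: compound 4

The source may hold more compounds than are shown below. What is called first, only, known or untested is meant among the compounds shown, and "the series" means these compounds.

In an in vitro assay on HEK385-7 cells for displacement of a labelled ligand from prostaglandin D2 receptor 2 (Homo sapiens) (on this read-out higher numbers stand for weaker inhibition and lower numbers for stronger inhibition), compound 3 `O=C(O)Cc1sc(C(c2ccccc2)c2ccc(F)c(F)c2)nc1-c1ccc(F)cc1` gives 10 nM, the second highest of three numbers. Its nearest neighbour is compound 1 `O=C(O)Cc1sc(C(c2ccccc2)c2ccccc2)nc1-c1ccc(F)cc1`, which gives 8.7 nM; the step of a 1.1-fold higher number from compound 1 to compound 3 (0.06 log units; within the scatter). Furthest is compound 2 `O=C(O)Cc1sc(C(c2ccccc2)c2ccc(Cl)cc2)nc1-c1ccc(F)cc1`, which gives 14 nM; the step of a 1.4-fold lower number from compound 2 to compound 3 (0.15 log units; within the scatter). The remaining measured step of a 1.6-fold higher number from compound 1 to compound 2 (0.21 log units; within the scatter). Compound 4 `O=C(O)Cc1sc(C(c2ccccc2)c2ccc(O)cc2)nc1-c1ccc(F)cc1` differs from compound 3 by 4-hydroxyphenyl in place of 3,4-difluorophenyl on a saturated chain carbon bound to two aromatic carbons. The steps from compound 1 to compound 3 and from compound 2 to compound 3 concern the same place, and both fall within the scatter, so aryl changes there have so far left this assay flat. Going by the values given here, none of the measured changes brings in a hydrogen-bond donor, so the hydroxyl is untested. The expectation for compound 4 is therefore a step within the scatter, a 1.2-fold higher number from compound 3 to compound 4 (0.08 log units; within the scatter). Compound 4 is estimated at 12 nM, in the range 5 nM to 30 nM.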

Compound 4, half-maximal inhibitory concentration: 3.4 nM
Estimate against measurement, compound 4: 3.5-fold (0.55 log units) above; measured number below the stated range.
By their numbers in this assay, from the lowest: compound 4; then compounds 1, 3 and 2 (each within the scatter of the next).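

Going by these compounds alone, at the saturated chain carbon bound to two aromatic carbons, 4-hydroxyphenyl is the first aryl change to move the number in this assay beyond the scatter (as a modest step: a 2.9-fold lower number from compound 3 to compound 4 (0.47 log units; beyond the scatter)). The same holds against the 4-chlorophenyl and the unsubstituted phenyl (respectively read as a 4.1-fold lower number from compound 2 to compound 4 (0.61 log units; beyond the scatter) and a 2.6-fold lower number from compound 1 to compound 4 (0.41 log units; beyond the scatter)), so this position is not flat to every aryl change, and compound 4 alone of the four carries a hydrogen-bond donor. No supporting data bear on the origin of this step.

From the compounds shown here alone, whether the donor itself matters stays open: a methoxy or an amine in place of the hydroxy would separate the two readings.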